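The compounds below may be only part of what the source reports. "The series", "measured", "known", "first", "only" and "open" are said of these compounds alone.

In a functional assay on HCC827 cells (Homo sapiens) for antiproliferative activity, read by MTT assay, with a stated time of 72 h (on this read-out higher numbers stand for weaker inhibition and lower numbers for stronger inhibition), compound 1 `CN1CCN(c2ccc(Nc3ncc4nc(Nc5ccc(F)cc5)n([C@H]5CCCNC5)c4n3)cc2)CC1` gives 38 nM, while compound 2 `CNC(=O)CN1CC[C@H](n2c(Nc3ccc(F)cc3)nc3cnc(Nc4ccc(N5CCN(C)CC5)cc4)nc32)C1` gives 1520 nM, the higher of the two numbers. Compound 3 `CN1CCN(c2ccc(Nc3ncc4nc(Nc5ccc(F)cc5)n([C@H]5CCN(S(=O)(=O)C6CC6)C5)c4n3)cc2)CC1` departs from compound 2 by cyclopropylsulfonyl in place of (methylcarbamoyl)methyl on an amine nitrogen in a ring. Among the measured compounds shown here, the only measured step, a 40-fold higher number from compound 1 to compound 2 (1.60 log units; beyond the scatter), is large, but it replaced piperidin-3-yl, so it bears only indirectly on this exchange. For the measured compounds named here, no measured step compares two groups at this nitrogen. The expected step, a 1.5-fold lower number from compound 2 to compound 3 (0.18 log units; within the scatter), is therefore none beyond the scatter, leaning slightly lower. The estimate for compound 3 is 1000 nM, with an expected range of 200 nM to 5000 nM.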

Compound 3, half-maximal inhibitory concentration: 7.5 nM
Compound 3: middle estimate off by 130-fold (2.12 log units), on the high side, and the stated range ends above it.
By their numbers in this assay, from the lowest: compound 3; then compound 1; then compound 2.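

In this assay, the group on the amine nitrogen of the five-membered ring can move the number strongly by itself, with a 200-fold lower number from compound 2 to compound 3 (2.31 log units; beyond the scatter), so the high number of compound 2 does not follow from that ring as such. With cyclopropylsulfonyl on this nitrogen, the pyrrolidin-3-yl group even gives a lower number than the piperidin-3-yl group, with a 5.1-fold lower number from compound 1 to compound 3 (0.70 log units; beyond the scatter). Nothing available here explains either step. From the compounds shown here alone, it remains open whether a methylsulfonyl or an acetyl group on this nitrogen would also give a low number, and what cyclopropylsulfonyl would do on the nitrogen of piperidin-3-yl.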